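This account rests on a few compounds, and the source may have more. Where it says the series, first, only, none or still open, it means among the compounds named here.

Measured compounds:
Compound 1, `O=C(/C=C/c1ccccc1)Oc1ccc(-c2cc(=S)ss2)cc1`: 9500 nM
Compound 2, `CC(C(=O)Oc1ccc(C(N)=S)cc1)c1ccc(C(=O)c2ccccc2)cc1`: 16300 nM
Compound 3, `NC(=S)c1ccc(OC(=O)/C=C/c2ccccc2)cc1`: 17700 nM

In an ADME assay for pharmacokinetics, read by spectrophotometry, in phosphate buffer, with a stated time of 5 min, tested at 40 uM, at a dose of 40 uM, in the presence of a further agent that is not named here (a lower number here means less compound in the circulation, a higher number more compound in the circulation at the dose given), compound 3 gives 17700 nM and compound 1 gives 9500 nM. The two differ in one place, (a group of 6 heavy atoms (3 carbon, 3 sulfur; one five-membered aromatic ring with 2 hetero atoms) in place of a group of 3 heavy atoms (1 carbon, 1 nitrogen, 1 sulfur; no ring), on an aromatic carbon), and the step was a 1.9-fold lower number from compound 3 to compound 1 (0.27 log units; within the scatter). Compound 2 gives 16300 nM in this assay; its value and that of compound 3 lie within the scatter of each other, as do its value and that of compound 1. How the core of compound 2 differs from the core of compound 3 is not broken down here.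

Compound 4, `CC(C(=O)Oc1ccc(-c2cc(=S)ss2)cc1)c1ccc(C(=O)c2ccccc2)cc1`, has not yet been measured in this assay. It stands to compound 2 as compound 1 stands to compound 3: a group of 6 heavy atoms (3 carbon, 3 sulfur; one five-membered aromatic ring with 2 hetero atoms) in place of a group of 3 heavy atoms (1 carbon, 1 nitrogen, 1 sulfur; no ring), on an aromatic carbon. The place lines of the two changes read the same, so this is the same change made on a different core. Going by the values given here, the only guide to its size is the step seen before, and that step was within the scatter, so a step of about the same size is expected here, a 1.8-fold lower number from compound 2 to compound 4 (0.26 log units; within the scatter), resting on compound 3 and compound 1 with a 1.9-fold lower number from compound 3 to compound 1 (0.27 log units; within the scatter). For compound 4 the expected value in this assay is 9000 nM, likely between 4500 nM and 18000 nM.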

Compound 4, maximal plasma concentration in the ADME assay: 14200 nM
Compound 4: middle estimate off by 1.6-fold (0.20 log units), on the low side, and the stated range covers the measured number.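

In the ADME assay, putting the ring-bearing group of 6 heavy atoms in place of the group of 3 heavy atoms gave a 1.1-fold lower number from compound 2 to compound 4 (0.06 log units; within the scatter), and the two cores agree: the same change on two cores in the ADME assay, a 1.9-fold lower number (0.27 log units; within the scatter) from compound 3 to compound 1 and a 1.1-fold lower number (0.06 log units; within the scatter) from compound 2 to compound 4, 1.6-fold (0.21 log units) apart, within the scatter of two such steps So within these four compounds the change carries over, but what carries over is a step too small to tell from the scatter, not a drop of reliable size, and two cores cannot establish a general rule. In a physicochemical assay for pharmacokinetics, read by spectrophotometry, in phosphate buffer, with a stated time of 5 min, tested at 40 uM, in the presence of a further agent that is not named here (on this read-out lower numbers stand for a shorter-lived compound and higher numbers for a longer-lived compound), compound 2 gives 0.163 h and compound 4 gives 0.0567 h and here the same change does give a step beyond the scatter, yet this single pair cannot show whether that step would hold on another core: the measured half-life of compound 2, 0.163 h, and of compound 4, 0.0567 h, a 2.9-fold lower number (0.46 log units; beyond the scatter)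

The compounds shown have only these two groups at this aromatic carbon, so it remains open how an amine or a carboxylic acid there would compare. From the compounds shown here alone, it also remains open whether the step would hold on a third core, such as one with an amide in place of the ester.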